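Trimethoxyphenyl Pyrazolopyrimidines: From Phenyl to Methylindolyl

The source may report more compounds than this note shows. Statements on the series, on what has been measured and on what is new or still open speak of the compounds shown alone.

Measured compounds:
- compound 1, `COc1cc(-c2ccnc3cc(-c4ccc(F)cc4)nn23)cc(OC)c1OC`, 3800 nM
- compound 2, `COc1cc(-c2ccnc3cc(-c4ccc(Cl)cc4)nn23)cc(OC)c1OC`, 3070 nM
- compound 3, `COc1cc(-c2ccnc3cc(-c4ccccc4)nn23)cc(OC)c1OC`, 208 nM

In a functional assay on A549 cells (Homo sapiens) for inhibition, read by CCK-8 assay, with a stated time of 48 h (a higher number here means a weaker inhibitor, a lower number a stronger inhibitor), compound 3 gives the lowest number of the three. Its nearest neighbour is compound 2, which stands a 15-fold lower number from compound 2 to compound 3 (1.17 log units; beyond the scatter), and the furthest is compound 1, with an 18-fold lower number from compound 1 to compound 3 (1.26 log units; beyond the scatter). The two halogenated compounds themselves differ only by a 1.2-fold lower number from compound 1 to compound 2 (0.09 log units; within the scatter), a difference within the scatter.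

Compound 4, `COc1cc(-c2ccnc3cc(-c4ccc5ccn(C)c5c4)nn23)cc(OC)c1OC`, has not yet been measured. It differs from compound 3 by 1-methyl-1H-indol-6-yl in place of phenyl on an aromatic carbon. Among the compounds with values here, no measured step covers such a ring enlargement directly. Within the data shown here, the only related steps are those from compound 3 to its substituted analogues, where adding a single halogen on the phenyl ring gave a large loss in this assay. Growing the phenyl into a fused bicyclic system is a larger change still, so compound 4 is expected to lose ground against compound 3, though the size of the step is uncertain. Compound 4 is therefore estimated at 1000 nM in this assay, within a range of 200 nM to 5000 nM, which corresponds to an expected step of a 4.8-fold higher number from compound 3 to compound 4 (0.68 log units; beyond the scatter).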

Compound 4, half-maximal inhibitory concentration: 829 nM
Compound 4: the middle estimate sits 1.2-fold (0.08 log units) above what was measured, within the range that was stated.
By their numbers in this assay, from the lowest: compound 3; then compound 4; then compounds 2 and 1 (each within the scatter of the next).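

In this assay, this position tolerates the larger 1-methyl-1H-indol-6-yl group at a modest cost relative to phenyl, with a 4.0-fold higher number from compound 3 to compound 4 (0.60 log units; beyond the scatter) in place of the large losses seen with the halogens. The same group also outperforms both halogenated phenyl groups, with a 3.7-fold lower number from compound 2 to compound 4 (0.57 log units; beyond the scatter) and a 4.6-fold lower number from compound 1 to compound 4 (0.66 log units; beyond the scatter), so among these four compounds the larger group at this position does not give the highest number. Nothing available explains this order.

The compounds shown leave open whether the methyl of the 1-methyl-1H-indol-6-yl group contributes to this result. They also leave open how a pyridyl ring, or a phenyl ring carrying an amine or a carboxylic acid, would behave at this position.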